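Trading Methoxy for Trifluoromethyl on an Aromatic Ring

The source may report more compounds than this note shows. Statements on the series, on what has been measured and on what is new or still open speak of the compounds shown alone.

Of the compounds shown here, two built on the same core have been tested in a functional assay on MDA-MB-231 cells (Homo sapiens) for antiproliferative activity, with a stated time of 4 days; on this read-out higher numbers stand for weaker inhibition and lower numbers for stronger inhibition. Compound 2 `CCCCc1ccc2[nH]c(-c3ccc(OC)cc3)c(/C=N/NC(=O)c3ccc(OC)cc3)c2c1` gives 61 nM, the lower of the two numbers, while compound 1 `CCCCc1ccc2[nH]c(-c3ccc(C(F)(F)F)cc3)c(/C=N/NC(=O)c3ccc(Cl)cc3)c2c1` gives 329 nM, a gap beyond the usual scatter of repeat measurements. Compound 3 `CCCCc1ccc2[nH]c(-c3ccc(C(F)(F)F)cc3)c(/C=N/NC(=O)c3ccc(OC)cc3)c2c1` is still unmeasured. It is compound 2 with trifluoromethyl in place of methoxy on an aromatic carbon, para to a large group (trifluoromethyl in place of methoxy on an aromatic carbon). Among the compounds with values here, no measured pair isolates this change. The nearest guide is compound 1, which carries the same trifluoromethyl at 329 nM but also has a second difference from compound 2. A clear move towards weaker inhibition is therefore expected in this assay, with an expected 3.3-fold higher number from compound 2 to compound 3 (0.52 log units; beyond the scatter). The estimated value for compound 3 is 200 nM, within an expected range of 80 nM to 450 nM.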

Compound 3, half-maximal inhibitory concentration: 284 nM
For compound 3 the middle estimate is 1.4-fold (0.15 log units) below the measured one, and the stated range covers the measured number.
By their numbers in this assay, from the lowest: compound 2; then compounds 3 and 1 (each within the scatter of the next).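

Seen alone for the first time in this assay, trifluoromethyl in place of methoxy on this aromatic carbon gives a 4.7-fold higher number from compound 2 to compound 3 (0.67 log units; beyond the scatter) and so weakens inhibition on its own. With trifluoromethyl held in place, methoxy in place of chloro on an aromatic carbon gives a 1.2-fold lower number from compound 1 to compound 3 (0.06 log units; within the scatter) and stays within the scatter, so this read-out does not separate those two groups in this setting. No measurement shown here accounts for the effect of the trifluoromethyl change.

From the compounds shown here alone, it remains open how an amine or a hydroxyl group would fare on the carbon that carries methoxy in compound 2. Also open, going by these compounds, is whether the step from methoxy to trifluoromethyl would keep its size with chloro in place of the second methoxy group.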